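Chloro on the Shared Core of Compound 2

The source may report more compounds than this note shows. Statements on the series, on what has been measured and on what is new or still open speak of the compounds shown alone.

In a functional assay on PC-3 cells (Homo sapiens) for cytotoxicity, read by MTT assay, with stated times of 48 h and 4 h (a lower number here means a stronger inhibitor, a higher number a weaker inhibitor), compound 2 `O=[N+]([O-])c1ccc(/C=C/c2nc(NCCN3CCCCC3)c3ccccc3n2)cc1` gives 25600 nM. That value lies within the scatter of compound 3 `CCN(CC)CCCNc1nc(/C=C/c2ccc([N+](=O)[O-])cc2)nc2ccccc12`, which gives 15400 nM, while compound 1 `COc1ccc(/C=C/c2nc(NCCN3CCCCC3)c3ccccc3n2)cc1OC` stands clearly higher at 78500 nM. Compound 2 therefore belongs to the lower pair of the three numbers.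

Compound 4 `O=[N+]([O-])c1ccc(/C=C/c2nc(NCCN3CCCCC3)c3cc(Cl)ccc3n2)cc1` differs from compound 2 at a single place on the shared core: chloro in place of hydrogen on an aromatic carbon. Two measured steps give some sense of scale. Placing 4-nitrophenyl where 3,4-dimethoxyphenyl stood gave a 3.1-fold lower number from compound 1 to compound 2 (0.49 log units; beyond the scatter), and placing (diethylamino)methyl where piperidin-1-yl stood gave a 1.7-fold lower number from compound 2 to compound 3 (0.22 log units; within the scatter). Among the measured compounds shown here, neither step touches this aromatic carbon, and no measured compound carries chloro, so the data offer no direction for the change. For the measured compounds named here, they show only that single changes in this small set moved the number modestly at most. No step beyond the scatter is therefore expected in this assay, and the middle of the estimate stays close to compound 2 at 25600 nM. The estimated step is a 1.3-fold lower number from compound 2 to compound 4 (0.11 log units; within the scatter). Compound 4 is expected at 20000 nM, with an estimated range from 7000 nM to 50000 nM.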

Compound 4, half-maximal inhibitory concentration: > 100000 nM
Compound 4: a limit, no number; the forecaster's own chance of this, stated with the estimate: 5%; middle value at least 5.0-fold (0.69 log units) away from the limit.
By their numbers in this assay, from the lowest: compounds 3 and 2 (each within the scatter of the next); then compound 1. At a limit, above all of these: compound 4.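

In this assay, chloro in place of hydrogen on an aromatic carbon of the shared core, meta to a fused ring and para to a fused ring, gives an at least 3.9-fold higher number from compound 2 to compound 4 (0.59 log units; beyond the scatter). Among the compounds shown here, the earlier steps touched only the group on the double-bonded chain or the amine side chain, so this is the first sign that the core itself responds to change: one heavy atom here moves the number beyond the scatter and towards a weaker inhibitor, just as the exchange of 3,4-dimethoxyphenyl for 4-nitrophenyl moved it beyond the scatter in the other direction in a 3.1-fold lower number from compound 1 to compound 2 (0.49 log units; beyond the scatter). The reading for compound 4 is a limit and not a number, so the step has a lower bound but no measured size: the limit of > 100000 nM in this assay, at which 1 of the 4 values shown sits.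

The compounds shown leave open whether fluoro, methyl or an amine on this aromatic carbon would shift the number in the same direction, or whether the shift belongs to chloro alone. They also leave open whether chloro at this place would raise the number on the side chain of compound 3 or with the 3,4-dimethoxyphenyl group of compound 1.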